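Moving a fluorine around the sulfonyl-linked ring

The compounds below may be only part of what the source reports. "The series", "measured", "known", "first", "only" and "open" are said of these compounds alone.

Compound 1 `COCC1CCN(c2c(S(=O)(=O)c3ccc(F)cc3)cnc3cc(F)ccc23)CC1` was tested in an assay on isolated protein for displacement of a labelled ligand from metabotropic glutamate receptor 5 (Homo sapiens), with a stated time of 60 min, tested at 1 uM (on this read-out higher numbers stand for more inhibition at the one concentration tested (going by the name of the read-out) and lower numbers for less inhibition), and gives 76.1%. Compound 2 `Cc1ccc(S(=O)(=O)c2cnc3cc(Cl)ccc3c2N2CCC(C)CC2)cc1` gives 94%, and compound 3 `CC1CCN(c2c(S(=O)(=O)c3ccc(F)c(F)c3)cnc3cc(F)ccc23)CC1` gives 94%. Compound 1 thus stands lowest of the three, and both gaps to compound 2 and to compound 3 lie beyond the usual scatter. Compound 4 `COCC1CCN(c2c(S(=O)(=O)c3cccc(F)c3)cnc3cc(F)ccc23)CC1` keeps every atom of compound 1 but joins them differently: 3-fluorophenyl in place of 4-fluorophenyl on a sulfonyl sulfur. Among the measured compounds shown here, no measured pair shows this same change, so its effect can only be guessed. A step from compound 1 to compound 4 that stays within the scatter, perhaps leaning slightly downward, is expected: a number 6.1 percentage points lower from compound 1 to compound 4 (within the scatter). For compound 4 the estimated inhibition is 70%, with a range from 50% to 88%.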

Compound 4, a percentage reported as inhibition, at one concentration (the size of the read-out at that concentration, not a potency): 70.5%
For compound 4 the middle estimate is 0.5 percentage points below the measured one, and the stated range covers the measured number.
By their numbers in this assay, from the lowest: compounds 4 and 1 (each within the scatter of the next); then compounds 2 and 3 (each within the scatter of the next).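

Placing 3-fluorophenyl in place of 4-fluorophenyl on a sulfonyl sulfur gives a number 5.6 percentage points lower from compound 1 to compound 4 (within the scatter) in this assay. This first single-place comparison therefore shows that, at the one concentration tested, moving the fluorine within this ring causes no change beyond the scatter. No supporting measurement bears on this result.

As far as these compounds go, whether a plain phenyl or a pyridine ring on the same sulfur would read alike remains open. So does whether this fluorine move gives a similar result on other versions of the shared core, as only one such pair is shown.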